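A few compounds are considered here, and "the series" means these few. Any claim that something is new, unique, unknown or untested is made for them only; others in the source may bear on it.

Compound 1 `COc1ccc(S(=O)(=O)N2CCc3cccc(-c4ccc(N)cc4)c32)cc1` gives 249 nM
Compound 2 `COc1ccc(S(=O)(=O)N2CCc3cccc(-c4ccccc4)c32)cc1` gives 120 nM

For the measured compounds named here, in a functional assay on KB cells (Homo sapiens) for inhibition, with a stated time of 72 h (on this read-out lower numbers stand for stronger inhibition and higher numbers for weaker inhibition), compound 2 holds the lower of the two numbers, and compound 1 is its only measured neighbour. Compound 3 `COc1ccc(S(=O)(=O)N2CCc3cccc(-c4ccc(O)cc4)c32)cc1` departs from compound 2 by a single change, phenyl to 4-hydroxyphenyl, with hydroxy in place of hydrogen on an aromatic carbon as the counted difference. Going by the values given here, one measured step bears on this. Compound 1 carries an amino group on the same ring, and removing it gave a 2.1-fold lower number from compound 1 to compound 2 (0.32 log units; beyond the scatter) as a modest change beyond the scatter. Read in reverse, that step suggests a small rise in the number when a group enters there, although no hydroxy compound has yet been measured to confirm it. The expected size of the change is a 1.6-fold higher number from compound 2 to compound 3 (0.20 log units; within the scatter) in this assay and it could prove to lie within the scatter. For compound 3 the estimate is 190 nM with an expected range from 90 nM to 400 nM around it.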

Compound 3, half-maximal inhibitory concentration: 129 nM
Beside the measured number, compound 3's estimate is 1.5-fold (0.17 log units) above it; measured number inside the range.
By their numbers in this assay, from the lowest: compounds 2, 3 and 1 (each within the scatter of the next, the first and the last beyond it).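

In this assay the hydroxy group on the aromatic carbon para to a large group gives a 1.1-fold higher number from compound 2 to compound 3 (0.03 log units; within the scatter), so, unlike the amino group, it opens no gap beyond the scatter from the unsubstituted phenyl of compound 2. The exchange of amino for hydroxy at this same place gives a 1.9-fold lower number from compound 1 to compound 3 (0.29 log units; within the scatter), which means that compound 3 cannot be separated from either neighbour, although those two neighbours do stand apart, with a 2.1-fold lower number from compound 1 to compound 2 (0.32 log units; beyond the scatter) as their step. No measurement is available that accounts for the different outcomes with these two groups.

As far as these compounds go, whether a methoxy group, a carboxylic acid or a longer chain at this place would also stay within the scatter of compound 2 remains open. So does whether hydroxy would give the same result on the other carbons of this ring.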